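The compounds below may be only part of what the source reports. "The series", "measured", "known", "first", "only" and "open" are said of these compounds alone.

Measured in an ADME assay on HEp-2 cells (Homo sapiens) for cytotoxicity; a lower number here means that less compound is tolerated, a higher number that more compound is tolerated
- compound 1 `CC(=O)NCc1ccc2c(c1)nc(Cn1c(=O)n(C(C)C)c3ccccc31)n2CCC(C)C` gives 178000 nM
- compound 2 `CC(C)CCn1c(Cn2c(=O)n(CC(=O)O)c3ccccc32)nc2cc(C(=N)N)ccc21` gives 173000 nM

Compound 1 and compound 2 stand level, within the scatter of each other. Compound 3 `CC(C)CCn1c(Cn2c(=O)n(C(C)C)c3ccccc32)nc2cc(CO)ccc21` carries hydroxy in place of acetamido on a saturated chain carbon bound to an aromatic carbon, so acetamidomethyl becomes hydroxymethyl (hydroxy in place of acetamido on a saturated chain carbon bound to an aromatic carbon). For the measured compounds named here, no measured step shows this change in this assay, so the only guide is the level held by compound 2 at 173000 nM and compound 1. No step beyond the scatter is expected, and the estimated step is a 1.4-fold lower number from compound 1 to compound 3 (0.14 log units; within the scatter). For compound 3 the expected value is 130000 nM, with an estimated range from 50000 nM to 250000 nM.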

Compound 3, half-maximal cytotoxic concentration: 31600 nM
For compound 3 the middle estimate is 4.1-fold (0.61 log units) above the measured one; the measured number lies below the stated range.
By their numbers in this assay, from the lowest: compound 3; then compounds 2 and 1 (each within the scatter of the next).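

In this assay, for the compounds shown here, hydroxy in place of acetamido on a saturated chain carbon bound to an aromatic carbon gives a 5.6-fold lower number from compound 1 to compound 3 (0.75 log units; beyond the scatter), the first step that can be read, and shows that the group at this position matters. Both groups carry the same counts of hydrogen-bond donors and acceptors, with heavy atoms going from 4 to 1. No measurement at hand accounts for the step.

From the compounds shown here alone, whether losing acetamido or gaining hydroxy drives it stays open. An amine or a carboxylic acid on the same saturated chain carbon would help separate the two.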